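Dimethylamino on the sulfonyl sulfur of compound 1

The source may report more compounds than this note shows. Statements on the series, on what has been measured and on what is new or still open speak of the compounds shown alone.

Measured in a physicochemical assay for solubility, in phosphate buffer, measured as kinetic solubility, at pH 7.4, tested at 250 uM; on this read-out higher numbers stand for higher solubility and lower numbers for lower solubility:
- compound 1 `CCCCCCNc1ccc(C(=O)O)cc1S(N)(=O)=O`: 238000 nM
- compound 2 `CCCCCCCCNc1ccc(C(=O)O)cc1S(N)(=O)=O`: > 250000 nM

In this assay, going by the values given here, compound 1 gives 238000 nM, the only actual number available. Compound 2 gives > 250000 nM, which is a limit of the assay and not a number. Compound 1 therefore stands close to the limit of > 250000 nM in this assay, at which 1 of the 2 values shown sits.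

Compound 3 `CCCCCCNc1ccc(C(=O)O)cc1S(=O)(=O)N(C)C` has not yet been measured. It differs from compound 1 by dimethylamino in place of amino on a sulfonyl sulfur, with dimethylamino in place of amino on a sulfonyl sulfur.

Among the compounds with values here, the only measured step is an at least 1.0-fold higher number from compound 1 to compound 2 (0.02 log units; that floor lies within the scatter). That step lies on a saturated chain carbon, so it bears only indirectly on a change at the sulfonyl sulfur. Compound 1 at 238000 nM leaves little measurable room for a rise, so no change beyond the scatter is expected. The estimated step is a 1.3-fold lower number from compound 1 to compound 3 (0.10 log units; within the scatter). The estimate for compound 3 is 190000 nM, with an expected range of 80000 nM to 250000 nM.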

Compound 3, solubility: 243000 nM
Estimate against measurement, compound 3: 1.3-fold (0.11 log units) below; the measured number falls inside the stated range.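

In this assay, dimethylamino in place of amino on a sulfonyl sulfur gives a 1.0-fold higher number from compound 1 to compound 3 (0.01 log units; within the scatter). Going by these compounds alone, this is the first reading at this position rather than on the saturated chain, and it shows that the sulfonyl sulfur can carry dimethylamino, which has no hydrogen-bond donor, with no change beyond the scatter. The reading can show little more than that, because the values lie close to the top of the measurable range: the limit of > 250000 nM in this assay, at which 1 of the 3 values shown sits.

As far as these compounds go, it remains open whether a group such as methylamino, or a bulkier one such as piperidine, on the sulfonyl sulfur would also stay within the scatter of compound 1. Also open, from the compounds shown here alone, is how an ester or an amide in place of the carboxylic acid would read in this assay with dimethylamino on the sulfonyl sulfur.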